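The source may report more compounds than this note shows. Statements on the series, on what has been measured and on what is new or still open speak of the compounds shown alone.

Compound 1 `COc1ccc(OC(=O)c2cn(-c3ccccc3)nc2-c2ccncc2)cc1`: > 100000 nM in a functional assay on MDA-MB-231 cells (Homo sapiens) for cytotoxicity, read by MTT assay, with a stated time of 48 h (a lower number here means a stronger inhibitor, a higher number a weaker inhibitor), which is a limit of the assay and not a number.
Compound 2 `CCc1ccc(OC(=O)c2cn(-c3ccccc3)nc2-c2ccncc2)cc1`: > 100000 nM in this assay, again a limit of the assay rather than a number.

Among the compounds with values here, both measured values therefore sit at the same limit, described as the limit of > 100000 nM in this assay, at which 2 of the 2 values shown sit, and the one step between them, a step that the two limits leave unreadable from compound 1 to compound 2, cannot be read in either direction or size. Compound 2 thus stands only as a limit in this assay, with no number to place it more precisely.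

Compound 3 `CC(C)c1cccc(OC(=O)c2cn(-c3ccccc3)nc2-c2ccncc2)c1` differs from compound 2 in one place: 3-isopropylphenyl in place of 4-ethylphenyl on an oxygen next to a carbonyl group. Within the data shown here, no measured step bears on this change, since the only step available is itself unreadable. What can be said is that compound 2 in this assay gives > 100000 nM, a limit, and that the change keeps the ester and the shared core untouched. The expectation for compound 3 is therefore that it too most likely reaches only a limit, with an estimated step of a number no higher from compound 2 to compound 3 (the limit leaves the size open) that is not expected to exceed the scatter. Compound 3 is expected to give about 100000 nM, with a range of 30000 nM to 300000 nM.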

Compound 3, half-maximal inhibitory concentration: > 100000 nM
Compound 3 ended at the assay's limit; the forecaster's own chance of this, stated with the estimate: 80%; the middle value lies on the limit itself.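

In this assay compound 3 gives > 100000 nM, a limit of the assay and not a number, so its steps to compound 1 and compound 2 cannot be read. The three compounds share one limit: the limit of > 100000 nM in this assay, at which 3 of the 3 values shown sit.

With no number among them, the compounds shown leave open how the 4-methoxyphenyl, 4-ethylphenyl and 3-isopropylphenyl groups compare with one another.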